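Compound 3: replacing the group on the aromatic nitrogen

The source may hold more compounds than are shown below. What is called first, only, known or untested is meant among the compounds shown, and "the series" means these compounds.

In an ADME assay on FHC cells (Homo sapiens) for cytotoxicity, read by resazurin assay, with a stated time of 48 h (on this read-out lower numbers stand for higher toxicity in this test and higher numbers for lower toxicity in this test), compound 1 (`COc1ccc(S(=O)(=O)Nc2ccc3oc(-c4ccc(NS(=O)(=O)c5cc(Br)ccc5OC)cc4)nc3c2)cc1`) gives > 100000 nM and this is a limit of the assay. Compound 2 (`COc1ccc(S(=O)(=O)Nc2ccc3oc(-c4ccc(NS(=O)(=O)c5cc(F)ccc5OC)cc4)nc3c2)cc1`) gives > 100000 nM and this too is a limit, so it stands without a number. Within the data shown here, the only measured step is a step that the two limits leave unreadable from compound 1 to compound 2 and it gives no size to carry forward. Compound 3 (`COc1ccc(S(=O)(=O)Nc2ccc3oc(-c4ccc(NC(=O)C5CCN(C(C)=O)CC5)cc4)nc3c2)cc1`) differs from compound 2 by a group of 11 heavy atoms (8 carbon, 1 nitrogen, 2 oxygen; one six-membered non-aromatic ring with 1 hetero atom) in place of a group of 12 heavy atoms (7 carbon, 3 oxygen, 1 fluorine, 1 sulfur; one six-membered aromatic ring of carbon only), on a nitrogen on an aromatic ring and the group that enters is (1-acetylpiperidin-4-yl)carbonyl. Among the measured compounds shown here, no measured step covers a replacement of this kind. For the measured compounds named here, no shift beyond the scatter is expected in this assay and no direction can be argued, and a further result at the limit is likely because the limit of > 100000 nM in this assay, at which 2 of the 2 values shown sit, and nothing measured so far falls short of it. The expected step is a number no higher from compound 2 to compound 3 (the limit leaves the size open) and it remains an estimate. For compound 3 the expected value is 100000 nM with an estimated range of 40000 nM to 200000 nM in this test.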

Compound 3, half-maximal cytotoxic concentration: > 100000 nM
Compound 3 was reported as a limit; the forecaster's own chance of this, stated with the estimate: 70%; the middle value sits exactly at the limit.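

In this assay compound 3 gives > 100000 nM, which is a limit of the assay, and the steps among compound 1, compound 2 and compound 3 cannot be read. The compounds shown leave open the half-maximal cytotoxic concentration of each compound and how far either replacement moves it.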